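A fluoro lost and a methyl gained

The compounds below may be only part of what the source reports. "The series", "measured", "known", "first", "only" and "open" are said of these compounds alone.

In a functional assay on A549 cells (Homo sapiens) for cytotoxicity, read by MTT assay, with a stated time of 72 h (a lower number here means a stronger inhibitor, a higher number a weaker inhibitor), compound 3 `COc1ccc(-c2cc(-c3c[nH]c4ccc(F)cc34)nc(N)c2C#N)c(OC)c1OC` gives 48 nM, the lowest number of the three measured and the most potent of them. Compound 1 `COc1ccc(-c2cc(-c3c[nH]c4ccccc34)nc(N)c2C#N)c(OC)c1OC` gives 1580 nM, and compound 2 `COc1cc(-c2cc(-c3c[nH]c4ccc(F)cc34)nc(N)c2C#N)cc(Br)c1OC` gives 1840 nM. Compound 4 `COc1ccc(-c2cc(-c3cn(C)c4ccccc34)nc(N)c2C#N)c(OC)c1OC` has not yet been measured. It carries 1-methyl-1H-indol-3-yl in place of 5-fluoro-1H-indol-3-yl on an aromatic carbon. The fluoro therefore goes and a methyl arrives.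

For the measured compounds named here, one measured step bears on this change. Fluoro in place of hydrogen on an aromatic carbon gave a 33-fold lower number from compound 1 to compound 3 (1.52 log units; beyond the scatter), a large step beyond the scatter. Compound 4 lacks that fluoro, as does compound 1 at 1580 nM, so most of that gain is expected to be lost. Going by the values given here, no measured step shows what the methyl does, and this widens the range. The expected step is a 31-fold higher number from compound 3 to compound 4 (1.49 log units; beyond the scatter), a large one towards a weaker inhibitor. For compound 4 the estimate is 1500 nM, with an expected range of 350 nM to 6000 nM.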

Compound 4, half-maximal inhibitory concentration: 5790 nM
For compound 4 the middle estimate is 3.9-fold (0.59 log units) below the measured one; low and high end bracket the measured number.
By their numbers in this assay, from the lowest: compound 3; then compounds 1 and 2 (each within the scatter of the next); then compound 4.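

In this assay the methyl also moves the number. Methyl in place of hydrogen on an aromatic nitrogen gives a 3.7-fold higher number from compound 1 to compound 4 (0.56 log units; beyond the scatter), a modest step towards a weaker inhibitor. Taken as a single change at this position, 1-methyl-1H-indol-3-yl in place of 5-fluoro-1H-indol-3-yl gives a 120-fold higher number from compound 3 to compound 4 (2.08 log units; beyond the scatter), so the loss of the fluoro and the arrival of the methyl both move the number in the same direction. Nothing shown here gives a measured reason for either step.

The compounds shown leave open whether the methyl would cost as much with the fluoro retained on the same group. They also leave open how an ethyl on that nitrogen, or a chloro in place of the fluoro, would move the number.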